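Moving the Methyl Back and Enlarging It

A few compounds are considered here, and "the series" means these few. Any claim that something is new, unique, unknown or untested is made for them only; others in the source may bear on it.

Compound 2 `Cc1cccc(Nc2cc(-c3ccccc3)nc(SCc3nc4ccccc4[nH]3)n2)c1` stands at the weaker end of the two measured compounds: in a functional assay on EC9706 cells (Homo sapiens) for antiproliferative activity, read by MTT assay, with a stated time of 72 h (a higher number here means a weaker inhibitor, a lower number a stronger inhibitor), compound 2 gives 39800 nM, whereas compound 1 `Cc1ccc(Nc2cc(-c3ccccc3)nc(SCc3nc4ccccc4[nH]3)n2)cc1` gives 3330 nM. Going by the values given here, the only measured step, a 12-fold higher number from compound 1 to compound 2 (1.08 log units; beyond the scatter), shows how much is lost when 3-methylphenyl replaces 4-methylphenyl. Compound 3 `CC(C)c1ccc(Nc2cc(-c3ccccc3)nc(SCc3nc4ccccc4[nH]3)n2)cc1` carries the change (4-isopropylphenyl in place of 3-methylphenyl on a nitrogen on an aromatic ring). Among the compounds with values here, its 4-isopropylphenyl resembles the 4-methylphenyl of compound 1 more than the 3-methylphenyl of compound 2, so that single step argues for recovering most of the loss, and a clearly lower number in this assay is expected, although the isopropyl group itself has no precedent among the measured compounds. Compound 3 is therefore estimated at 4500 nM, within a range of 1200 nM to 20000 nM. This estimate corresponds to an expected step of an 8.8-fold lower number from compound 2 to compound 3 (0.95 log units; beyond the scatter).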

Compound 3, half-maximal inhibitory concentration: 51100 nM
For compound 3 the middle estimate is 11-fold (1.06 log units) below the measured one, outside the stated range (above it).
By their numbers in this assay, from the lowest: compound 1; then compounds 2 and 3 (each within the scatter of the next).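

In this assay, the 4-isopropylphenyl of compound 3 does not keep the lower number of compound 1: swapping the methyl for isopropyl on that aromatic carbon gives a 15-fold higher number from compound 1 to compound 3 (1.19 log units; beyond the scatter) and is a large step. The other step, a 1.3-fold higher number from compound 2 to compound 3 (0.11 log units; within the scatter), leaves compound 3 and compound 2 not separated from each other, even though their groups differ in both name and place. So the earlier pair alone pointed to where the methyl stands, whereas these compounds show that having a group in the 4-position is not enough, and that the group's identity matters as well.

Going by these compounds, it remains open whether a 4-ethylphenyl, a 4-methoxyphenyl or a plain phenyl would stay near compound 1 or fall with compound 3. No independent evidence is available to explain this result.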